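The source may hold more compounds than are shown below. What is called first, only, known or untested is meant among the compounds shown, and "the series" means these compounds.

Measured compounds:
compound 1, `CC(C)NC(=S)N/N=C1\CC(c2ccc(O)cc2)Oc2cc(O)ccc21`: 60400 nM
compound 2, `CCCNC(=S)N/N=C1\CC(c2ccc(O)cc2)Oc2cc(O)ccc21`: 74700 nM

Both numbers come from a functional assay on DU-145 cells (Homo sapiens) for cytotoxicity, read by MTT assay, with a stated time of 72 h; on this read-out lower numbers stand for stronger inhibition and higher numbers for weaker inhibition. Compound 2 holds the highest of the two numbers; its nearest neighbour is compound 1, and the step between them, a 1.2-fold higher number from compound 1 to compound 2 (0.09 log units; within the scatter), lies within the scatter, so the two cannot be put in order. Compound 3, `CCCN(CCC)C(=S)N/N=C1\CC(c2ccc(O)cc2)Oc2cc(O)ccc21`, has not yet been measured. It differs from compound 2 by propyl in place of hydrogen on an amide-type nitrogen. Within the data shown here, no measured step speaks to this change: the only step recorded, from compound 1 to compound 2, swaps one group on the nitrogen for another and leaves the hydrogen in place, so it tells nothing about a second propyl entering. Among the measured compounds shown here, with no relevant precedent, no step beyond the scatter is expected for a 1.0-fold higher number from compound 2 to compound 3 (0.00 log units; within the scatter), and the range is kept wide. Compound 3 is therefore estimated at 75000 nM in this assay, between 30000 nM and 200000 nM.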

Compound 3, half-maximal inhibitory concentration: 62100 nM
Beside the measured number, compound 3's estimate is 1.2-fold (0.08 log units) above it; the range from low to high includes it.
By their numbers in this assay, from the lowest: compounds 1, 3 and 2 (each within the scatter of the next).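

In this assay, among these compounds, propyl in place of hydrogen on the amide-type nitrogen, the change from propylamino to dipropylamino, gives a 1.2-fold lower number from compound 2 to compound 3 (0.08 log units; within the scatter) and so leaves no step that can be read, even though this nitrogen now carries a second chain and no hydrogen. Dipropylamino in place of isopropylamino on the thiocarbonyl carbon likewise gives a 1.0-fold higher number from compound 1 to compound 3 (0.01 log units; within the scatter) and shows that the isopropyl, propyl and dipropyl forms on this nitrogen cannot be put in order. No evidence is available that bears on this result.

Going by these compounds, whether a longer chain such as octyl, a phenyl ring or a chain ending in an amine on this nitrogen would move the number beyond the scatter stays open. Also open, on these data alone, is whether a change elsewhere on the shared core, such as a methoxy group in place of a hydroxyl, would do so.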